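Compound 4 against the pyrazolyl lead

A few compounds are considered here, and "the series" means these few. Any claim that something is new, unique, unknown or untested is made for them only; others in the source may bear on it.

Compound 1 `NC1CCC(Nc2nc(NCc3ccc(Br)cc3)c3ncn(C4CCCC4)c3n2)CC1`: 1480 nM
Compound 2 `COc1ccccc1-c1ccc(CNc2nc(NC3CCC(N)CC3)nc3c2ncn3C2CCCC2)cc1`: 545 nM
Compound 3 `NC1CCC(Nc2nc(NCc3ccc(-n4cccn4)cc3)c3ncn(C4CCCC4)c3n2)CC1`: 220 nM

All values come from a functional assay on G-361 cells (Homo sapiens) for inhibition, with a stated time of 72 h; on this read-out lower numbers stand for stronger inhibition and higher numbers for weaker inhibition. Compound 3 has the lowest number of the three, with a 2.5-fold lower number from compound 2 to compound 3 (0.39 log units; beyond the scatter) and a 6.7-fold lower number from compound 1 to compound 3 (0.83 log units; beyond the scatter). Compound 4 `NC1CCC(Nc2nc(NCc3ccc(-c4cccs4)nc3)c3ncn(C4CCCC4)c3n2)CC1` carries 6-(thiophen-2-yl)pyridin-3-yl in place of 4-(1H-pyrazol-1-yl)phenyl on a saturated chain carbon bound to a nitrogen on an aromatic ring. The nearest evidence is modest: a 2.7-fold lower number from compound 1 to compound 2 (0.43 log units; beyond the scatter), and the two steps above. Among the measured compounds shown here, no measured step changes the six-membered aromatic ring, so the expectation is uncertain. A small move towards a higher number is expected in this assay. The expected step is a 1.8-fold higher number from compound 3 to compound 4 (0.26 log units; within the scatter). The estimate for compound 4 is 400 nM, with an expected range of 130 nM to 1200 nM.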

Compound 4, half-maximal inhibitory concentration: 150 nM
Compound 4: middle estimate off by 2.7-fold (0.43 log units), on the high side; the range from low to high includes it.
By their numbers in this assay, from the lowest: compounds 4 and 3 (each within the scatter of the next); then compound 2; then compound 1.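

In this assay, 6-(thiophen-2-yl)pyridin-3-yl in place of 4-(1H-pyrazol-1-yl)phenyl gives a 1.5-fold lower number from compound 3 to compound 4 (0.17 log units; within the scatter), so this position tolerates a change in both aromatic rings without a step beyond the scatter. Set against 4-bromophenyl, the same group gives a 9.9-fold lower number from compound 1 to compound 4 (0.99 log units; beyond the scatter), a larger step than compound 3 showed. No measurement bears on the cause of either step.

The two ring changes enter together, leaving their separate contributions open. Also open, as far as these compounds go, is how an amine or a carboxylic acid in place of the thiophen-2-yl group would read.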